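The compounds below may be only part of what the source reports. "The series", "measured", "known", "first", "only" and "open" are said of these compounds alone.

Compound 1 `COc1cc(-c2ccnc3cc(-c4ccc(Cl)cc4)nn23)cc(OC)c1OC`: 3070 nM
Compound 2 `COc1ccc(-c2cc3nccc(-c4cc(OC)c(OC)c(OC)c4)n3n2)cc1[N+](=O)[O-]`: > 10000 nM
Compound 3 `Cc1ccc(-c2cc3nccc(-c4ccc(F)cc4)n3n2)cc1`: > 10000 nM

Among the measured compounds shown here, in a functional assay on A549 cells (Homo sapiens) for inhibition, read by CCK-8 assay, with a stated time of 48 h (on this read-out lower numbers stand for stronger inhibition and higher numbers for weaker inhibition), compound 1 gives 3070 nM, the only finite number among the three measured compounds. Compound 2 reaches only the limit of this assay, > 10000 nM. Compound 3 likewise reaches only the limit, > 10000 nM. For the measured compounds named here, that two of the three values sit at this limit is the one piece of evidence on hand (the limit of > 10000 nM in this assay, at which 2 of the 3 values shown sit), and it leaves compound 1 standing alone as the sole compound with a measured inhibitory concentration.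

Compound 4 `COc1cc(-c2ccnc3cc(-c4ccc5cnn(C)c5c4)nn23)cc(OC)c1OC` is not yet measured. It differs from compound 1 in one place (1-methyl-1H-indazol-6-yl in place of 4-chlorophenyl on an aromatic carbon). Going by the values given here, no step between two measured compounds is available to calibrate this change, so any expectation rests on compound 1 alone. The author expects a modest step toward stronger inhibition, estimated as a 2.0-fold lower number from compound 1 to compound 4 (0.31 log units; beyond the scatter), though a step within the scatter or in the other direction cannot be ruled out. Compound 4 is therefore estimated at 1500 nM in this assay, with a range from 300 nM to 8000 nM.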

Compound 4, half-maximal inhibitory concentration: 233 nM
Estimate against measurement, compound 4: 6.4-fold (0.81 log units) above, outside the stated range (below it).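

In this assay, the place on an aromatic carbon next to the ring nitrogen proves sensitive to the group it carries: 1-methyl-1H-indazol-6-yl in place of 4-chlorophenyl gives a 13-fold lower number from compound 1 to compound 4 (1.12 log units; beyond the scatter). Among the compounds shown here, the earlier compounds offered no step at all, so this is the first sign that the choice of group here can shift the number by more than the usual scatter. One step cannot separate the added five-membered aromatic ring, its 2 hydrogen-bond acceptors and the loss of chlorine, and nothing on hand gives a cause for the change.

The compounds shown leave open whether the methyl on the indazole is needed, and how a 1H-indazol-6-yl without it would fare. Also open, from the compounds shown here alone, is how a simple amine or a carboxylic acid would behave at this place.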